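Swapping one aryl group on a weak growth inhibitor

A few compounds are considered here, and "the series" means these few. Any claim that something is new, unique, unknown or untested is made for them only; others in the source may bear on it.

a functional assay on DU-145 cells (Homo sapiens) for inhibition, read by trypan blue exclusion, with a stated time of 96 h (a lower number here means a stronger inhibitor of growth, a higher number a weaker inhibitor of growth), gave these values:
Compound 1 `Cc1ccc(S/C(=C/c2ccc(N(C)C)cc2)C(=O)c2ccc(Cl)cc2)cc1` gives > 100000 nM as a limit
Compound 2 `CN(C)c1ccc(/C=C(/SCc2ccccc2Cl)C(=O)c2ccc(Cl)cc2)cc1` gives > 100000 nM as a limit
Compound 3 `Cc1cc(C)cc(/C=C(/Sc2ccc(Br)cc2)C(=O)c2ccc(Cl)cc2)c1` gives 10000 nM as a true number

Among the compounds with values here, compound 3 holds the only actual number of the three, since the other two results are limits of the assay and not numbers. Compound 4 `CN(C)c1ccc(/C=C(/Sc2ccc(Br)cc2)C(=O)c2ccc(Cl)cc2)cc1` differs from compound 3 in one place. The change is 4-(dimethylamino)phenyl in place of 3,5-dimethylphenyl on a double-bonded chain carbon bound to a double-bonded chain carbon and it puts 4-(dimethylamino)phenyl in place of 3,5-dimethylphenyl on a double-bonded chain carbon bound to a double-bonded chain carbon.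

Within the data shown here, the one measured step is a step that the two limits leave unreadable from compound 1 to compound 2 and so offers no size to carry over. Compound 1 and compound 2 do share 4-(dimethylamino)phenyl with compound 4, and the nearest evidence is the limit of > 100000 nM in this assay, at which 2 of the 3 values shown sit, for that pair. Two compounds make a hint and not a rule. Starting from compound 3 at 10000 nM in this assay a move towards weaker inhibition of growth is expected. A limit in place of a number is quite possible for compound 4. The expected change is a 5.0-fold higher number from compound 3 to compound 4 (0.70 log units; beyond the scatter) on this estimate. For compound 4 the expected value is 50000 nM with an estimated range from 12000 nM to 100000 nM in this reading.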

Compound 4, concentration for 50% growth inhibition: > 100000 nM
Compound 4: a limit, no number; the forecaster's own chance of this, stated with the estimate: 55%; middle value at least 2.0-fold (0.30 log units) away from the limit.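

In this assay, within the data shown here, placing 4-(dimethylamino)phenyl in place of 3,5-dimethylphenyl on a double-bonded chain carbon bound to a double-bonded chain carbon gives an at least 10-fold higher number from compound 3 to compound 4 (1.00 log units; beyond the scatter), the only readable step here, and it lies beyond the scatter. Compound 4 gives > 100000 nM, which is a limit of the assay and not a number. Neither compound 1 nor compound 2 had a partner differing from it at this position alone, but with 4-bromophenyl on the sulfur shared by compound 3 and compound 4, the swap now directly links 4-(dimethylamino)phenyl with weaker inhibition of growth, and all the compounds shown that carry this group sit at the same limit: the limit of > 100000 nM in this assay, at which 3 of the 4 values shown sit.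

As far as these compounds go, the steps among compound 1, compound 2 and compound 4 cannot be read, so the effect of the group on the sulfur remains unknown while 4-(dimethylamino)phenyl is present. From the compounds shown here alone, it also remains open whether a phenyl ring carrying a primary amine, a morpholine or a carboxylic acid in the same place would give a measurable number or stay at the limit.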